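A few compounds are considered here, and "the series" means these few. Any claim that something is new, unique, unknown or untested is made for them only; others in the source may bear on it.

Measured in a functional assay on OVCAR-3 cells (Homo sapiens) for cytotoxicity, read by MTT assay, with a stated time of 6 days; a lower number here means a stronger inhibitor, a higher number a weaker inhibitor:
Compound 1 `CC(=O)N[C@@H](CSC(=O)Nc1ccccc1F)C(=O)O`: > 200000 nM
Compound 2 `CC(=O)N[C@@H](CSC(=O)Nc1cccc(Cl)c1)C(=O)O`: > 200000 nM
Compound 3 `CC(=O)N[C@@H](CSC(=O)Nc1ccc(Br)cc1)C(=O)O`: > 200000 nM

Compound 1 gives no number in this assay: its reading of > 200000 nM is a limit of the assay. The readings for compound 2 and compound 3 are limits of the same kind, so no order can be drawn among the three. Taken together, the series shows (the limit of > 200000 nM in this assay, at which 3 of the 3 values shown sit).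

Compound 4 `CSc1ccccc1NC(=O)SC[C@H](NC(C)=O)C(=O)O` has not yet been measured. It keeps the core of compound 1 but carries methylsulfanyl in place of fluoro on an aromatic carbon, ortho to a large group: methylsulfanyl in place of fluoro on an aromatic carbon. Within the data shown here, no measured pair isolates a single change with numbers on both sides, so the size of this swap cannot be read directly from the data.

In this assay, no step beyond the usual scatter is expected, in either direction. This expectation rests on compound 1, whose reading is > 200000 nM, and on the other two compounds sharing that limit. The estimated change is a number no higher from compound 1 to compound 4 (the limit leaves the size open). The assay may well report only a limit again. Compound 4 is estimated at 200000 nM, with an expected range from 100000 nM to 300000 nM.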

Compound 4, half-maximal inhibitory concentration: > 200000 nM
Compound 4: a limit, no number; the forecaster's own chance of this, stated with the estimate: 80%; the middle value sits exactly at the limit.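

In this assay, compound 4 reads > 200000 nM, which is a limit of the assay and not a number. Among these compounds, compound 1 also gives only a limit, so no step from compound 1 to compound 4 can be read. The four compounds therefore leave open how methylsulfanyl or any of the other aromatic substituents shown affects the read-out, for all share one reading: the limit of > 200000 nM in this assay, at which 4 of the 4 values shown sit.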